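Amine variation on a fused triazolopyrimidine core, receptor 1 binding

This account rests on a few compounds, and the source may have more. Where it says the series, first, only, none or still open, it means among the compounds named here.

compound 1 `CCC(CC)Nc1nc(C)nc2c(-c3ccc(OC)nc3C)c(C)nn12` — 3.1 nM
compound 2 `CCCN(CCC)c1nc(C)nc2c(-c3c(C)cc(N(C)C)nc3C)c(C)nn12` — 14.9 nM
compound 3 `CCCN(CC1CC1)c1nc(C)nc2c(-c3ccc(OC)nc3C)c(C)nn12` — 1.6 nM

In an assay on cell membranes for displacement of a labelled ligand from corticotropin-releasing factor receptor 1 (Rattus norvegicus) (on this read-out higher numbers stand for weaker inhibition and lower numbers for stronger inhibition), compound 3 gives the lowest of the three numbers shown. Compound 1 lies within the scatter of it, while compound 2 sits beyond the scatter. Compound 4 `CCC[C@H](C)Nc1nc(C)nc2c(-c3ccc(OC)nc3C)c(C)nn12` alters the amine on the shared core: (1-methylbutyl)amino in place of (cyclopropylmethyl)(propyl)amino on an aromatic carbon. For the measured compounds named here, the one measured step at this place, a 1.9-fold lower number from compound 1 to compound 3 (0.29 log units; within the scatter), exchanged one amine for another and stayed within the scatter. A return to a secondary amine with a branched alkyl group, as in compound 1, is therefore expected to move this assay little. The step of a 1.6-fold higher number from compound 3 to compound 4 (0.19 log units; within the scatter) is expected to remain within the scatter. Compound 4 is estimated at 2.5 nM, with a range of 1 nM to 7 nM.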

Compound 4, half-maximal inhibitory concentration: 4.5 nM
Estimate against measurement, compound 4: 1.8-fold (0.26 log units) below; the range from low to high includes it.
By their numbers in this assay, from the lowest: compounds 3, 1 and 4 (each within the scatter of the next, the first and the last beyond it); then compound 2.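

In this assay, for the compounds shown here, the exchange of amines gives a 2.8-fold higher number from compound 3 to compound 4 (0.45 log units; beyond the scatter) and is the first step at this position to pass the scatter. With a hydrogen left on the nitrogen, a 1.5-fold higher number from compound 1 to compound 4 (0.16 log units; within the scatter) stays within the scatter, so 1-methylbutyl and pentan-3-yl are not told apart here. No measurement at hand accounts for either step.

Compound 4 loses the three-membered ring and gains the hydrogen-bond donor in one change, so the compounds shown do not say which of the two goes with the gap. A (cyclopropylmethyl)amino group on the same core would separate them, and the mirror-image 1-methylbutyl amine would test the stereocentre.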